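Trifluoromethyl exchanged for methylcarbamoyl on a weak inhibitor

The compounds below may be only part of what the source reports. "The series", "measured", "known", "first", "only" and "open" are said of these compounds alone.

Compound 3 `FC(F)(F)c1cccc(CNc2cc(C(F)(F)F)cc3[nH]ncc23)c1` was tested in an assay for inhibition of Indoleamine 2,3-dioxygenase 1 (Homo sapiens), with stated times of 10 min and 60 min (a lower number here means a stronger inhibitor, a higher number a weaker inhibitor), where compound 3 gives only a limit, > 100000 nM. Compound 1 `O=C(O)CNc1cccc(CNc2cc(C(F)(F)F)cc3[nH]ncc23)c1` also gives only a limit in this assay, > 100000 nM. Compound 2 `O=[N+]([O-])c1ccc(CNc2cc(Br)cc3[nH]ncc23)cc1` gives 6970 nM in this assay. The step from compound 1 to compound 3 a step that the two limits leave unreadable from compound 1 to compound 3 cannot be sized because of the limit of > 100000 nM in this assay, at which 2 of the 3 values shown sit.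

Compound 4 `CNC(=O)c1cccc(CNc2cc(C(F)(F)F)cc3[nH]ncc23)c1` differs from compound 3 by methylcarbamoyl in place of trifluoromethyl on an aromatic carbon. Among the compounds with values here, no measured step speaks directly to this exchange, and the one known step carries no readable size, so neither a direction nor a size can be taken from the data. Compound 4 is therefore expected to stay weak, with an estimated 80000 nM in this assay, between 10000 nM and 300000 nM. The step from compound 3 to compound 4 is expected to be an at least 1.2-fold lower number from compound 3 to compound 4 (0.09 log units; that floor lies within the scatter).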

Compound 4, half-maximal inhibitory concentration: > 100000 nM
Compound 4 gave a limit, no number; the forecaster's own chance of this, stated with the estimate: 60%; at least 1.2-fold (0.09 log units) between middle value and limit.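

The steps to compound 4 from compound 1 and from compound 3 cannot be read, because all three compounds give only a limit: the limit of > 100000 nM in this assay, at which 3 of the 4 values shown sit.

The compounds shown leave open whether methylcarbamoyl, trifluoromethyl and (carboxymethyl)amino differ at all in their effect on inhibition.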